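This account rests on a few compounds, and the source may have more. Where it says the series, first, only, none or still open, it means among the compounds named here.

Measured compounds:

Compound 1, `C[N+](C)(CCCCCCCCc1ccccc1)CCCCS(=O)(=O)[O-]` — in an assay on isolated protein for inhibition of squalene synthase (Rattus norvegicus) (on this read-out lower numbers stand for stronger inhibition and higher numbers for weaker inhibition), compound 1 gives 8000 nM.
Compound 2, `C[N+](C)(CCCCc1ccc(-c2ccccc2)cc1)CCCCS(=O)(=O)[O-]` — in this assay compound 2 gives 25000 nM.

Of the two numbers in hand, compound 2 holds the higher one; its nearest neighbour is compound 1, whose number is lower by a margin beyond the scatter. Among the compounds with values here, compound 1 carries a flexible chain ending in a single aromatic ring, whereas compound 2 carries a shorter chain ending in a two-ring biphenyl unit; since no step between them is computed, only the two values themselves can be compared.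

Compound 3, `C[N+](C)(CCCCc1ccc(Cc2ccccc2)cc1)CCCCS(=O)(=O)[O-]`, has not yet been measured in this assay. It arises from compound 2 by one change: benzyl in place of phenyl on an aromatic carbon. One carbon is inserted between the two aromatic rings, so the outer ring is carried on a link of the kind seen, at greater length, in compound 1. On that basis a modest move toward a lower number is expected, but one that may not clear the scatter; the expected step is a 1.9-fold lower number from compound 2 to compound 3 (0.28 log units; within the scatter). For compound 3 in this assay the estimate is 13000 nM, with a range from 4000 nM to 40000 nM.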

Compound 3, half-maximal inhibitory concentration: 200000 nM
For compound 3 the middle estimate is 15-fold (1.19 log units) below the measured one; measured number outside the range, above it.
By their numbers in this assay, from the lowest: compound 1; then compound 2; then compound 3.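

In this assay, the aromatic carbon para to a large group proves sensitive to this change: benzyl in place of phenyl gives an 8.0-fold higher number from compound 2 to compound 3 (0.90 log units; beyond the scatter) and not the small shift that might have been supposed. The counted differences are slight, since benzyl has 7 heavy atoms against 6 for phenyl, both carry one six-membered aromatic ring of carbon only, and neither has hydrogen-bond donors or acceptors or a net charge, so these counts alone give no warning of a step beyond the scatter. Nothing available bears on why the number rises at this position.

The compounds shown leave open whether the rise continues or reverses with other groups on this aromatic carbon, such as phenethyl, phenoxy or benzoyl, and whether a carboxylic acid or an amine on the outer ring would change the reading. They also leave open whether benzyl in place of phenyl would produce a step of similar size if the four-carbon chain leading to this ring were replaced by a longer chain.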